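The source may hold more compounds than are shown below. What is called first, only, known or untested is meant among the compounds shown, and "the series" means these compounds.

Measured in a physicochemical assay for solubility, in phosphate buffer; a higher number here means a more soluble compound, a lower number a less soluble compound:
- Compound 1 `Cc1cc(N[C@H](CCCCN)C(=O)NO)cc(C)c1F`: > 5 ug/mL
- Compound 2 `Cc1cc(N[C@H](CCCCNCc2ccccc2F)C(=O)NO)cc(C)c1F`: > 5 ug/mL

Neither entry is an exact number. Going by these compounds, compound 2 gives > 5 ug/mL, which is a limit, so its true position is unknown. The picture so far is simply (the limit of > 5 ug/mL in this assay, at which 2 of the 2 values shown sit).

Compound 3 `Cc1cc(N[C@H](CCCCNCc2cccc(F)c2)C(=O)NO)cc(C)c1F` has not yet been measured. In compound 3, 3-fluorophenyl takes the place of 2-fluorophenyl on a saturated chain carbon bound to an amine nitrogen: 3-fluorophenyl in place of 2-fluorophenyl on a saturated chain carbon bound to an amine nitrogen. The two compounds have the same atoms, joined differently.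

Among the measured compounds shown here, only one measured step bears on this change: a step that the two limits leave unreadable from compound 1 to compound 2. There, 2-fluorobenzyl took the place of hydrogen on an amine nitrogen. For the measured compounds named here, that step offers no size to carry over, and no measured step shows what a change between these two fluorophenyl groups does in this assay. The expected step, a step that the limit leaves unreadable from compound 2 to compound 3, is therefore none beyond the usual scatter, with no direction favoured. For compound 3, the estimate is 8 ug/mL, with an expected range of 5 ug/mL to 30 ug/mL. A report as a limit alone is also likely.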

Compound 3, solubility: > 5 ug/mL
Compound 3 gave a limit, no number (the forecaster's own chance of this, stated with the estimate: 85%); the middle value is on the limit's open side.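

No step can be read among compound 1, compound 2 and compound 3, since each result in this assay is a limit and not a number: the limit of > 5 ug/mL in this assay, at which 3 of the 3 values shown sit.

Going by these compounds, how far each compound's true value lies past that limit stays open, as does whether 2-fluorobenzyl and 3-fluorobenzyl give different results in this assay.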